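The source may hold more compounds than are shown below. What is called first, only, known or untested is meant among the compounds shown, and "the series" means these compounds.

Three compounds have been measured in a functional assay on MCF7 cells (Homo sapiens) for antiproliferative activity, read by MTT assay, with a stated time of 72 h; a lower number here means a stronger inhibitor, a higher number a weaker inhibitor:

compound 1 `CC1=CCC2C(CC[C@@]2(C)O)C(C)(C)C1CC[C@@H]1[C@@]2(C)CC[C@@H](O)C(C)(C)O[C@@H]2CC[C@]1(C)O`: 44500 nM
compound 2 `CC1=CC[C@H]2[C@H](CC[C@]2(C)O)C(C)(C)[C@@H]1CC[C@H]1[C@]2(C)CC[C@H](OC(=O)c3ccc(C)cc3)C(C)(C)O[C@H]2CC[C@@]1(C)O`: > 50000 nM
compound 3 `CC1=CC[C@H]2[C@H](CC[C@]2(C)O)C(C)(C)[C@@H]1CC[C@H]1[C@]2(C)CC/C(=N/OC(=O)c3ccccc3)C(C)(C)O[C@H]2CC[C@@]1(C)O`: 25600 nM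

The value given for compound 2 is a limit of this assay and not a number; compound 2 sits at the limit of > 50000 nM in this assay, at which 1 of the 3 values shown sits. Compound 1 and compound 3 each have a number, and no step between any pair of these compounds has been worked out, so their values are taken simply as they stand. Compound 4 `CC1=CC[C@H]2[C@H](CC[C@]2(C)O)C(C)(C)[C@@H]1CC[C@H]1[C@]2(C)CC[C@H](OC(=O)c3cccc(C(F)(F)F)c3)C(C)(C)O[C@H]2CC[C@@]1(C)O` has not yet been measured in this assay. It is made from compound 2 by one change (3-(trifluoromethyl)phenyl in place of 4-methylphenyl on a carbonyl carbon). Since compound 2 gives only a limit, the expected step of a number no higher from compound 2 to compound 4 (the limit leaves the size open) cannot be anchored to a number, and no movement beyond the usual scatter is expected from this exchange of one aromatic ring for another. Compound 4 is therefore estimated at 50000 nM, with a range from 20000 nM to 120000 nM, and a fair chance that this assay again reports only a limit for compound 4.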

Compound 4, half-maximal inhibitory concentration: 37900 nM
Compound 4: middle estimate off by 1.3-fold (0.12 log units), on the high side; measured number inside the range.
By their numbers in this assay, from the lowest: compounds 3, 4 and 1 (each within the scatter of the next). At a limit, above all of these: compound 2.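

Placing 3-(trifluoromethyl)phenyl instead of 4-methylphenyl on this carbonyl carbon turns a limit into a readable number in this assay, with an at least 1.3-fold lower number from compound 2 to compound 4 (0.12 log units; that floor lies within the scatter). Compound 4 at 37900 nM still sits high on this scale, so a number can be read at this position, but it does not show a strong inhibitor. The true size of this step stays unknown because compound 2 gives only a limit: the limit of > 50000 nM in this assay, at which 1 of the 4 values shown sits.

Going by these compounds, whether another group on this carbonyl carbon, such as a pyridine ring, an aminophenyl ring or a simple alkyl chain, would bring the number down remains open. On these data alone, it also remains open whether the trifluoromethyl group itself matters, or whether other substituents on the same aromatic ring would read the same.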